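Extending a Propyl Ether and an Aryl Methyl by One Carbon

The source may hold more compounds than are shown below. What is called first, only, known or untested is meant among the compounds shown, and "the series" means these compounds.

Of the compounds shown here, three on a shared core have been measured in a physicochemical assay for lipophilicity; a lower number here means a more polar compound, a higher number a more lipophilic compound. Compound 1 `CCCOc1ccc2[nH]c(-c3ccc(OC)cc3)c(C3=C(Br)C(=O)NC3=O)c2c1` gives 3.12. Compound 2 `CCCCOc1ccc2[nH]c(-c3ccc(OC)cc3)c(C3=C(Br)C(=O)NC3=O)c2c1` differs from compound 1 by methyl in place of hydrogen on a saturated chain carbon, three bonds along the chain from an oxygen on an aromatic ring. In this assay compound 2 gives 3.43, so that the step of a number 0.31 log units higher from compound 1 to compound 2 (beyond the scatter). Compound 3 `COc1cccc(-c2[nH]c3ccc(C)cc3c2C2=C(Br)C(=O)NC2=O)c1` gives 3.12, level with compound 1 at the digits printed; the difference between the cores of compound 1 and compound 3 is not broken down here.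

Compound 4 `CCc1ccc2[nH]c(-c3cccc(OC)c3)c(C3=C(Br)C(=O)NC3=O)c2c1` has not yet been measured. It differs from compound 3 by methyl in place of hydrogen on a saturated chain carbon bound to an aromatic carbon. Going by the values given here, this is the same kind of change as the one from compound 1 to compound 2, with one difference around the place: in compound 2 the methyl enters three bonds along the chain from an oxygen on an aromatic ring, whereas in compound 4 it enters on a saturated chain carbon bound to an aromatic carbon.

Only one measured example of this kind of change exists among these compounds. On that basis the expectation for compound 4 is that this assay will move by about a number 0.33 log units higher from compound 3 to compound 4 (beyond the scatter), because the step of a number 0.31 log units higher from compound 1 to compound 2 (beyond the scatter) for the related change. Among the compounds with values here, compound 4 is therefore estimated at 3.45 in this assay, with a range from 3.2 to 3.75, the width reflecting that the change sits in a different place than in the one measured pair.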

Compound 4, partition coefficient: 3.35
For compound 4 the middle estimate is 0.10 log units above the measured one, and the stated range covers the measured number.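

In this assay, methyl in place of hydrogen on a saturated chain carbon bound to an aromatic carbon gives a number 0.23 log units higher from compound 3 to compound 4 (within the scatter), while the related change on the core of compound 1 gave a number 0.31 log units higher from compound 1 to compound 2 (beyond the scatter). The change therefore gives a step beyond the scatter in one pair but not in the other, so this series does not show that a clear step carries over from one core to the other; nor does it show that the core alters the result, as the two pairs differ in both the core and the place of the change, and each case rests on a single pair. Nothing available here accounts for the size of either step.

The compounds shown leave open whether a longer chain, such as propyl or butyl in place of the ethyl of compound 4, would give a step beyond the scatter on this core. They also leave open how this assay would respond to an amine or a carboxylic acid at the end of that chain, and whether the same change would give a similar step on further cores.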